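Trifluoromethoxyphenyl Swap Tested Against Cell Tolerance

The compounds below may be only part of what the source reports. "The series", "measured", "known", "first", "only" and "open" are said of these compounds alone.

Three compounds sharing one core were run in an ADME assay on HeLa cells (Homo sapiens) for cytotoxicity, read by ATP content, with a stated time of 3 days; a lower number here means that less compound is tolerated, a higher number that more compound is tolerated. Compound 1 `O=c1n(Cc2cc3cnccc3n2CCCC(F)(F)F)c2cnccc2n1C1CC1` returns only a limit of the assay, > 50000 nM. Compound 2 `CC(C)(C)n1c(=O)n(Cc2cc3cc(Cl)ccc3n2CCCS(C)(=O)=O)c2cnccc21` likewise returns a limit, > 50000 nM. Compound 3 `COc1ccc(-n2c(=O)n(Cc3cc4cc(Cl)ccc4n3CCCC#N)c3cnccc32)c(C)c1` also returns a limit, > 50000 nM. Compound 3 thus stands where every measured compound stands, namely at the limit of > 50000 nM in this assay, at which 3 of the 3 values shown sit, so nothing measured here separates one compound from another and no order can be read among them. Compound 4 `N#CCCCn1c(Cn2c(=O)n(-c3ccc(OC(F)(F)F)cc3)c3ccncc32)cc2cc(Cl)ccc21` differs from compound 3 in one place: 4-(trifluoromethoxy)phenyl in place of 4-methoxy-2-methylphenyl on an aromatic nitrogen. Going by the values given here, no measured pair shows what this kind of change does in this assay, so the expectation rests on the three limits alone. With all measured compounds sitting at the limit of > 50000 nM in this assay, at which 3 of the 3 values shown sit, the step is expected to be none beyond the scatter, namely a number no higher from compound 3 to compound 4 (the limit leaves the size open). Compound 4 is therefore expected to give 50000 nM in this assay, most probably again reported as a limit rather than a number, within a range estimated from 25000 nM to 100000 nM.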

Compound 4, half-maximal cytotoxic concentration: > 50000 nM
Compound 4 was reported as a limit; the forecaster's own chance of this, stated with the estimate: 85%; the middle value lies on the limit itself.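

In this assay, compound 3 and compound 4 both return a limit rather than a number, so no step can be read between them: the limit of > 50000 nM in this assay, at which 4 of the 4 values shown sit.

The compounds shown leave open what 4-(trifluoromethoxy)phenyl in place of 4-methoxy-2-methylphenyl does to tolerance, and at what concentration any of these compounds would harm the cells.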